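Amide nitrogen substituents in the adenosine-derived series

A few compounds are considered here, and "the series" means these few. Any claim that something is new, unique, unknown or untested is made for them only; others in the source may bear on it.

Compound 1 `CCCCCCNC(=O)[C@H]1OC(n2cnc3c(N)ncnc32)[C@H](O)[C@@H]1O` carries a hexyl chain on the amide-type nitrogen. Among the measured compounds shown here, in an assay on cell membranes for binding affinity to 2-oxoglutarate receptor 1 (Rattus norvegicus), read by radioligand binding (a lower number here means a stronger inhibitor, a higher number a weaker inhibitor), compound 1 gives 19 nM, the lowest of the two numbers so far. For the measured compounds named here, compound 2 `Nc1ncnc2c1ncn2C1O[C@H](C(=O)NC2CC3CCC2C3)[C@@H](O)[C@H]1O` carries a bicyclic group on that nitrogen instead, and in this assay compound 2 gives 640 nM; the step of a 34-fold higher number from compound 1 to compound 2 (1.53 log units; beyond the scatter) is the only measured step, and it shows that exchanging the open chain for a ring-containing group on the amide-type nitrogen cost a great deal.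

Compound 3 `COc1ccc(CNC(=O)[C@H]2OC(n3cnc4c(N)ncnc43)[C@H](O)[C@@H]2O)cc1OC` is the next case: 3,4-dimethoxyphenyl in place of pentyl on a saturated chain carbon bound to an amide-type nitrogen. Going by the values given here, the saturated chain carbon bound to the amide-type nitrogen is kept, so the change sits one atom further out than the one from compound 1 to compound 2, but once more a ring enters where an open chain left. Among the compounds with values here, only the step of a 34-fold higher number from compound 1 to compound 2 (1.53 log units; beyond the scatter) bears on this, and it was large, so a clear weakening is expected in this assay, though probably a smaller one. For compound 3 the expected step is a 7.9-fold higher number from compound 1 to compound 3 (0.90 log units; beyond the scatter). For compound 3 the expected value in this assay is 150 nM, within 40 nM to 600 nM.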

Compound 3, inhibition constant: 140 nM
Compound 3: the middle estimate sits 1.1-fold (0.03 log units) above what was measured, and the stated range covers the measured number.
By their numbers in this assay, from the lowest: compound 1; then compound 3; then compound 2.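

In this assay the step of a 7.4-fold higher number from compound 1 to compound 3 (0.87 log units; beyond the scatter) shows that the position does not tolerate this change freely even when the saturated chain carbon bound to the amide-type nitrogen is kept, so a change further out on the substituent still registers beyond the scatter. Measured from the same compound, this modest step compares with the large step of a 34-fold higher number from compound 1 to compound 2 (1.53 log units; beyond the scatter), and among the three compounds the open hexyl chain of compound 1 still gives the lowest number. The change brings in the aromatic ring and the two methoxy groups together, and no information available here explains the step or assigns it to either part of the new group.

The compounds shown leave open whether a plain phenyl ring without methoxy groups would behave as 3,4-dimethoxyphenyl does, which would separate the ring from its substituents. On the open-chain side, it also remains unsettled how a longer chain such as octyl, or a hexyl chain ending in an amine or a carboxylic acid, would compare with compound 1 in this assay.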